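Swapping the end group on a thiophene sulfonamide series

The compounds below may be only part of what the source reports. "The series", "measured", "known", "first", "only" and "open" are said of these compounds alone.

Of the compounds shown here, three that share most of their skeleton have been tested in a functional assay on HL-60 cells (Homo sapiens) for inhibition, read by CCK-8 assay, with a stated time of 48 h; on this read-out higher numbers stand for weaker inhibition and lower numbers for stronger inhibition. Compound 1 `CC(C)c1ccc(Oc2ccc(O)c(O)c2)c(-c2ccsc2S(=O)(=O)NCCNC(=S)Nc2ccc([N+](=O)[O-])cc2)c1` gives 8800 nM. Compound 3 `CC(C)c1ccc(Oc2ccc(O)c(O)c2)c(-c2ccsc2S(=O)(=O)NCCNC(=O)Nc2cc(Cl)cc(Cl)c2)c1` differs from compound 1 in a single spot: a group of 11 heavy atoms (7 carbon, 1 nitrogen, 1 oxygen, 2 chlorine; one six-membered aromatic ring of carbon only) in place of a group of 12 heavy atoms (7 carbon, 2 nitrogen, 2 oxygen, 1 sulfur; one six-membered aromatic ring of carbon only), on an amine nitrogen. In this assay compound 3 gives 6500 nM. The step this change made is a 1.4-fold lower number from compound 1 to compound 3 (0.13 log units; within the scatter), so in this series the exchange left the number essentially where it was.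

Compound 2 `Cc1ccc(-c2ccsc2S(=O)(=O)NCCNC(=S)Nc2ccc([N+](=O)[O-])cc2)c(Oc2ccc(O)c(O)c2)c1` carries a different core from compound 1; the difference between the two cores is not broken down here. In this assay compound 2 gives 2900 nM, the lowest of the three numbers, and its gap to both compound 1 and compound 3 is beyond the usual scatter.

Compound 4 `Cc1ccc(-c2ccsc2S(=O)(=O)NCCNC(=O)Nc2cc(Cl)cc(Cl)c2)c(Oc2ccc(O)c(O)c2)c1` has not yet been measured. It stands to compound 2 exactly as compound 3 stands to compound 1: a group of 11 heavy atoms (7 carbon, 1 nitrogen, 1 oxygen, 2 chlorine; one six-membered aromatic ring of carbon only) in place of a group of 12 heavy atoms (7 carbon, 2 nitrogen, 2 oxygen, 1 sulfur; one six-membered aromatic ring of carbon only), on an amine nitrogen. The spot where the change is made is the same in both pairs, an amine nitrogen whose other neighbour is a saturated chain carbon, so this is the same change seen once before.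

Among the compounds with values here, since the one earlier instance, a 1.4-fold lower number from compound 1 to compound 3 (0.13 log units; within the scatter), stayed within the scatter, the expected step is a 1.4-fold lower number from compound 2 to compound 4 (0.14 log units; within the scatter), a small shift rather than a clear gain, and it rests on compound 1 and compound 3 alone. Compound 4 is therefore estimated at 2100 nM in this assay, with a likely range from 900 nM to 5000 nM.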

Compound 4, half-maximal inhibitory concentration: 3500 nM
Beside the measured number, compound 4's estimate is 1.7-fold (0.22 log units) below it, and the stated range covers the measured number.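

On the core of compound 2, putting (3,5-dichlorophenyl)carbamoyl in place of the earlier end group gives a 1.2-fold higher number from compound 2 to compound 4 (0.08 log units; within the scatter), so in this assay the number again stays essentially where it was. Set side by side, the two instances of this change agree with each other: the same change on two cores in this assay, a 1.4-fold lower number (0.13 log units; within the scatter) from compound 1 to compound 3 and a 1.2-fold higher number (0.08 log units; within the scatter) from compound 2 to compound 4, 1.6-fold (0.21 log units) apart, within the scatter of two such steps On these two cores, then, the exchange behaves as a neutral swap, but two pairs do not show that it would stay neutral on any other core, and steps this small cannot reveal whether the change has a slight real effect in either direction or whether it has opposite effects on the two cores.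

The incoming and outgoing end groups also differ in more than one feature at once, so these compounds leave open what each feature contributes on its own, and whether a different end group, such as one carrying a carboxylic acid or an amine, would move the number clearly. On these data alone, a longer chain leading to the amine nitrogen, and the behaviour of the same exchange on a third core, also remain open.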